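A Longer Hydroxycarbamoyl Chain on Compound 3

The compounds below may be only part of what the source reports. "The series", "measured", "known", "first", "only" and "open" are said of these compounds alone.

In a functional assay on A-431 cells (Homo sapiens) for antiproliferative activity, read by MTT assay, with a stated time of 72 h (on this read-out lower numbers stand for stronger inhibition and higher numbers for weaker inhibition), compound 1 `C=CC(=O)Nc1cc2c(Nc3ccc(OCc4cccc(F)c4)c(Cl)c3)ncnc2cc1OCc1cn(CCCC(=O)NO)nn1` gives 19900 nM, compound 2 `C=CC(=O)Nc1cc2c(Nc3ccc(OCc4cccc(F)c4)c(Cl)c3)ncnc2cc1OCc1cn(CCCCC(=O)NO)nn1` gives 18800 nM and compound 3 `C=CC(=O)Nc1cc2c(Nc3ccc(F)c(Cl)c3)ncnc2cc1OCc1cn(CCC(=O)NO)nn1` gives 22100 nM. These numbers lie within the usual scatter of one another, so compound 3 stands level with the other two.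

Compound 4 `C=CC(=O)Nc1cc2c(Nc3ccc(F)c(Cl)c3)ncnc2cc1OCc1cn(CCCC(=O)NO)nn1` differs from compound 3 by a single change: (hydroxycarbamoyl)methyl in place of hydroxycarbamoyl on a saturated chain carbon, two bonds along the chain from an aromatic nitrogen. Put simply, (hydroxycarbamoyl)methyl sits in place of hydroxycarbamoyl on a saturated chain carbon, two bonds along the chain from an aromatic nitrogen.

The closest evidence is the same swap made three bonds along the chain from an aromatic nitrogen, on a different core. That measured step is small, a 1.1-fold lower number from compound 1 to compound 2 (0.02 log units; within the scatter), and it stays within the scatter. Among the measured compounds shown here, it is only one pair, so it guides the expectation without settling it. No real shift is expected in this assay, and the estimated step is a 1.1-fold lower number from compound 3 to compound 4 (0.04 log units; within the scatter). The value expected for compound 4 is 20000 nM, with a likely range from 12000 nM to 33000 nM.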

Compound 4, half-maximal inhibitory concentration: 20700 nM
Compound 4: the middle estimate sits 1.0-fold (0.01 log units) below what was measured; low and high end bracket the measured number.
By their numbers in this assay, from the lowest: compounds 2, 1, 4 and 3 (each within the scatter of the next).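

Going from 2-(hydroxycarbamoyl)ethyl to 3-(hydroxycarbamoyl)propyl on the triazole brings no real shift in this assay (a 1.1-fold lower number from compound 3 to compound 4 (0.03 log units; within the scatter)). Among the compounds shown here, this chain extension had been seen on only one core, and it now reads alike on two, so the lack of a shift is no longer tied to a single compound pair: the same change on two cores in this assay, a 1.1-fold lower number (0.02 log units; within the scatter) from compound 1 to compound 2 and a 1.1-fold lower number (0.03 log units; within the scatter) from compound 3 to compound 4, 1.0-fold (0.00 log units) apart, within the scatter of two such steps. A second comparison, at a different place in the molecule, shows that fluoro in place of (3-fluorobenzyl)oxy on an aromatic carbon also stays within the scatter (a 1.0-fold higher number from compound 1 to compound 4 (0.02 log units; within the scatter)).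

The compounds shown leave open whether a much longer chain would separate from these values in this assay. They also leave open whether a carboxylic acid or a primary amide in place of hydroxycarbamoyl would do so.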